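The source may report more compounds than this note shows. Statements on the series, on what has been measured and on what is new or still open speak of the compounds shown alone.

Measured so far in an ADME assay on microsomes from liver (Mus musculus) for metabolic stability, with a stated time of 10 min; a lower number here means that less of the compound is left, a higher number that more of the compound is left:
- compound 1 `O=C(O)[C@H]1CC[C@H](C(=O)N2CC[C@](c3ccc(C(OCc4ccccc4OC(F)(F)F)(C(F)(F)F)C(F)(F)F)cc3)(S(=O)(=O)c3ccc(F)cc3)C2)CC1`: 81%
- compound 2 `O=C(O)[C@H]1CC[C@H](C(=O)N2CC[C@](c3ccc(C(OCc4c(F)cccc4Cl)(C(F)(F)F)C(F)(F)F)cc3)(S(=O)(=O)c3ccc(F)cc3)C2)CC1`: 87%

Only these two numbers are available, and compound 2, at 87%, stands level with compound 1 within the scatter. The next compound, compound 3 `COc1cccc(F)c1COC(c1ccc([C@]2(S(=O)(=O)c3ccc(F)cc3)CCN(C(=O)[C@H]3CC[C@H](C(=O)O)CC3)C2)cc1)(C(F)(F)F)C(F)(F)F`, differs from compound 2 by one change: methoxy in place of chloro on an aromatic carbon. In words, methoxy replaces chloro, turning 2-chloro-6-fluorobenzyl into 2-fluoro-6-methoxybenzyl. Going by the values given here, the single measured step bearing on this changes the same aromatic group: a number 6 percentage points higher from compound 1 to compound 2 (within the scatter). Among the compounds with values here, that step is small, and no measured compound carries the methoxy group, so the evidence is thin. No step beyond the scatter is therefore expected in this assay, with at most a slight downward lean. The expected change is a number 7 percentage points lower from compound 2 to compound 3 (within the scatter). Compound 3 is estimated at 80%, with an expected range of 64% to 92%.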

Compound 3, percent of the compound remaining: 88%
Beside the measured number, compound 3's estimate is 8 percentage points below it; measured number inside the range.
By their numbers in this assay, from the lowest: compounds 1, 2 and 3 (each within the scatter of the next).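

In this assay, methoxy in place of chloro on an aromatic carbon, ortho to a large group and meta to a fluoro group, reads as a number 1 percentage points higher from compound 2 to compound 3 (within the scatter). This adds an oxygen-linked group to a position so far shown only with chloro, and the reading stays level. The comparison with the 2-(trifluoromethoxy)phenyl compound reads as a number 7 percentage points higher from compound 1 to compound 3 (within the scatter), so all three benzyl variants sit within the scatter of one another, and nothing on hand gives a reason for these readings.

On these data alone, whether an amine such as dimethylamino or a longer ether chain such as ethoxy at this place would also stay level in this assay remains open. Any effect of this change on other properties of the series also remains open.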